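Bis-benzylidene cyclohexanones: bromine placement and glucosidase inhibition

A few compounds are considered here, and "the series" means these few. Any claim that something is new, unique, unknown or untested is made for them only; others in the source may bear on it.

Measured so far:
compound 1 `COc1ccc(/C=C2\CCC/C(=C\c3ccccc3)C2=O)c(OC)c1`: 41%
compound 2 `O=C1/C(=C/c2ccccc2)CCC/C1=C\c1ccccc1Br`: 46.8%
compound 3 `COc1ccc(OC)c(/C=C2\CCC/C(=C\c3ccccc3)C2=O)c1`: 43.8%

All three were tested in an assay on isolated protein for inhibition of Alpha glucosidase (Homo sapiens), with stated times of 5 min and 15 min, tested at 50 uM; a lower number here means less inhibition, a higher number more inhibition at the concentration tested (going by the name of the read-out). Compound 2 gives 46.8%, the highest of the three numbers; the nearest is compound 3 with 43.8%, the furthest compound 1 with 41%. Both gaps lie within the usual scatter of the read-out, so the three compounds are read as equivalent on these numbers, and no ordering among them is claimed.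

Compound 4 `O=C1/C(=C/c2ccccc2)CCC/C1=C\c1ccc(Br)cc1` has not yet been measured in this assay. It has the same atoms as compound 2, joined differently:
4-bromophenyl in place of 2-bromophenyl on a double-bonded chain carbon bound to a double-bonded ring carbon
Going by the values given here, no step between two measured compounds isolates this kind of change, so there is no measured step to lean on. The three measured numbers sit close together despite differing aryl substitution, which gives no reason to expect a step beyond the scatter in either direction. Compound 4 is therefore estimated at 44%, with a range of 30% to 58%, the expected step being a number 2.8 percentage points lower from compound 2 to compound 4 (within the scatter).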

Compound 4, a percentage reported as inhibition, at one concentration (the size of the read-out at that concentration, not a potency): 29.1%
Compound 4: the middle estimate sits 14.9 percentage points above what was measured; measured number outside the range, below it.
By their numbers in this assay, from the lowest: compound 4; then compounds 1, 3 and 2 (each within the scatter of the next).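

In this assay the bromine's place on the ring proves to be a change the read-out can resolve: 4-bromophenyl in place of 2-bromophenyl gives a number 17.7 percentage points lower from compound 2 to compound 4 (beyond the scatter) even though the two groups have the same atoms and the same counts. The earlier compounds shown here, all within the scatter of one another, gave no sign of this sensitivity, and this pair now separates compound 4 from the rest of the series on the location of one atom alone. No measured information available here accounts for the step, which rests on this single pair.

Open, going by these compounds, is whether 4-chlorophenyl and 2-chlorophenyl at this place would differ in the same direction, which would show if the step belongs to bromine or to the place itself. Also open, on these data alone, is how an amine or a carboxylic acid on this ring would read.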